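The source may report more compounds than this note shows. Statements on the series, on what has been measured and on what is new or still open speak of the compounds shown alone.

Of the compounds shown here, three have been tested in a toxicity assay on HepG2 cells (Homo sapiens) for inhibition, read by CellTiter-Glo, with a stated time of 48 h (a lower number here means a stronger inhibitor, a higher number a weaker inhibitor), and all three sit at the assay's limit. Compound 1 `CCOc1ccc2nc(C)cc(OCC(=O)Nc3cc(C)cc(C)c3)c2c1` gives > 100000 nM, which is a limit rather than a measured number. Compound 2 `COc1ccc2nc(C(F)(F)F)cc(OCC(=O)Nc3cc(C)cc(C)c3)c2c1` likewise gives > 100000 nM, again a limit. Compound 3 `COc1ccc2nc(C)cc(OCC(=O)Nc3c(C)cccc3C)c2c1` gives > 100000 nM, also a limit and not a number, so compound 3 stands at the same place as the other two, as the limit of > 100000 nM in this assay, at which 3 of the 3 values shown sit, shows. Compound 4 `COc1ccc2nc(C)cc(OCC(=O)Nc3ccncc3)c2c1` has not yet been tested in this assay; it differs from compound 3 by pyridin-4-yl in place of 2,6-dimethylphenyl on an amide-type nitrogen. With every measured value at the limit, no step beyond the usual scatter is expected, and compound 4 is estimated at 150000 nM (range 60000 nM to 400000 nM), meaning an expected step that the limit leaves unreadable from compound 3 to compound 4.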

Compound 4, half-maximal inhibitory concentration: > 100000 nM
Compound 4: no number, only a limit; the forecaster's own chance of this, stated with the estimate: 85%; the middle value does not contradict the limit.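

Compound 3 and compound 4 each give only a limit, so no step can be read between them: the limit of > 100000 nM in this assay, at which 4 of the 4 values shown sit.

The compounds shown leave open which change, if any, would bring a measurable value in this assay.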